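Ring nitrogen substituent on the amine core: ethyl to cyclohexyl

The source may hold more compounds than are shown below. What is called first, only, known or untested is meant among the compounds shown, and "the series" means these compounds.

Measured so far in an assay on HEK293 cells for positive allosteric modulation of metabotropic glutamate receptor 5 (Homo sapiens), read by FLIPR, with a stated time of 1 h; a higher number here means that more compound is needed for the effect, a lower number that less compound is needed:
compound 1 `O=C1NCCc2nc(C#Cc3ccccc3)sc21` gives 112 nM
compound 2 `O=C1NCCc2nc(C#Cc3ccccc3F)sc21` gives 1500 nM
compound 3 `CCN1CCc2nc(C#Cc3ccccc3)sc2C1` gives > 10000 nM, which is a limit of this assay and not a number

Compound 3 stands at the limit of > 10000 nM in this assay, at which 1 of the 3 values shown sits, so there is no number for it to set against the other two. Among the compounds with values here, the only step measured between two compounds, a 13-fold higher number from compound 1 to compound 2 (1.13 log units; beyond the scatter), concerns a change on the aromatic ring of the alkyne substituent and leaves the amine part of the core untouched.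

Compound 4 `C(#Cc1nc2c(s1)CN(C1CCCCC1)CC2)c1ccccc1` differs from compound 3 by cyclohexyl in place of ethyl on an amine nitrogen in a ring. Within the data shown here, no measured step touches this nitrogen, so the data give no calibrated step for the change; the one available step lies elsewhere in the molecule and does not transfer.

With compound 3 at a limit, compound 4 is expected to stay at or near that limit, the step that the limit leaves unreadable from compound 3 to compound 4 being only a guess. The estimate for compound 4 in this assay is 15000 nM, in the range 3000 nM to 60000 nM, with a real chance that only a limit is reported again.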

Compound 4, half-maximal effective concentration: > 10000 nM
Compound 4: a limit, no number (the forecaster's own chance of this, stated with the estimate: 70%); the middle value lies beyond the limit too.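

Compound 3 and compound 4 both stand at a limit, not a number, in this assay, so no step can be read for cyclohexyl in place of ethyl on this amine nitrogen: the limit of > 10000 nM in this assay, at which 2 of the 4 values shown sit.

From the compounds shown here alone, whether any other group on this nitrogen gives a number in this assay stays open.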